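From 3-fluorophenyl to 4-chlorophenyl on the shared core

The source may report more compounds than this note shows. Statements on the series, on what has been measured and on what is new or still open speak of the compounds shown alone.

Measured so far in a functional assay on U-251 cells (Homo sapiens) for antiproliferative activity, read by MTT assay, with a stated time of 48 h; a lower number here means a stronger inhibitor, a higher number a weaker inhibitor:
Compound 1 `COc1ccc(-c2nc3cccc(-c4cc(OC)c(OC)c(OC)c4)c3o2)cc1`: > 25000 nM (a limit of the assay)
Compound 2 `COc1cc(-c2cccc3nc(-c4cccc(F)c4)oc23)cc(OC)c1OC`: 2900 nM

Among the measured compounds shown here, compound 2 holds the only actual number in this assay, since the entry for compound 1 is a limit. Compound 3 `COc1cc(-c2cccc3nc(-c4ccc(Cl)cc4)oc23)cc(OC)c1OC` carries 4-chlorophenyl in place of 3-fluorophenyl on an aromatic carbon. For the measured compounds named here, one measured step bears on this, at the same carbon: an at least 8.6-fold lower number from compound 1 to compound 2 (0.93 log units; beyond the scatter). It shows that a swap there can move the number beyond the scatter, and the compound 1 end of it, with its 4-methoxyphenyl, is weak. A modest move toward a higher number is therefore expected, estimated as a 1.6-fold higher number from compound 2 to compound 3 (0.19 log units; within the scatter). Compound 3 is expected at 4500 nM, within an estimated range of 1200 nM to 18000 nM.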

Compound 3, half-maximal inhibitory concentration: 1600 nM
The estimate for compound 3 lay 2.8-fold (0.45 log units) above the measured number; the measured number falls inside the stated range.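

In this assay, 4-chlorophenyl and 3-fluorophenyl cannot be told apart at this carbon: a 1.8-fold lower number from compound 2 to compound 3 (0.26 log units; within the scatter) lies within the scatter. Chloro in place of methoxy gives an at least 15-fold lower number from compound 1 to compound 3 (1.19 log units; beyond the scatter), beyond the scatter, so a second replacement of 4-methoxyphenyl also moves the number well beyond the scatter. The entry for compound 1 is a limit of the assay, so this step is only a bound: the limit of > 25000 nM in this assay, at which 1 of the 3 values shown sits.

The compounds shown leave open how an amine or a carboxylic acid on this phenyl ring would read. They also leave open whether chloro at other ring carbons would read the same.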